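The source may hold more compounds than are shown below. What is called first, only, known or untested is meant among the compounds shown, and "the series" means these compounds.

Three measured compounds share one core and differ only in the aryl group on the amide-type nitrogen. Compound 1 `O=C(CSc1nc(Nc2ccccc2)c2ccccc2n1)Nc1ccccc1Cl` gives 14600 nM in a functional assay on PC-3 cells (Homo sapiens) for inhibition, read by MTT assay, with a stated time of 72 h; a higher number here means a weaker inhibitor, a lower number a stronger inhibitor. Compound 2 `O=C(CSc1nc(Nc2ccccc2)c2ccccc2n1)Nc1ccc(F)cc1` gives 9560 nM in this assay, and compound 3 `O=C(CSc1nc(Nc2ccccc2)c2ccccc2n1)Nc1ccc(Br)cc1` gives 8450 nM in this assay. Compound 3 holds the lowest of the three numbers, yet it stands within the scatter of the other two, as a 1.1-fold lower number from compound 2 to compound 3 (0.05 log units; within the scatter) and a 1.7-fold lower number from compound 1 to compound 3 (0.24 log units; within the scatter) show. The remaining step, a 1.5-fold lower number from compound 1 to compound 2 (0.18 log units; within the scatter), is equally small.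

Compound 4 `CCc1ccc(NC(=O)CSc2nc(Nc3ccccc3)c3ccccc3n2)cc1` has not yet been measured. It differs from compound 3 by ethyl in place of bromo on an aromatic carbon. For the measured compounds named here, the only measured step at the same aromatic carbon is the exchange of one halogen for another, a 1.1-fold lower number from compound 2 to compound 3 (0.05 log units; within the scatter), which did not rise above the scatter; the two steps that replace the whole aryl group, a 1.5-fold lower number from compound 1 to compound 2 (0.18 log units; within the scatter) and a 1.7-fold lower number from compound 1 to compound 3 (0.24 log units; within the scatter), stayed within it as well. Nothing measured here speaks for an exchange of bromo for ethyl having a larger effect than these. The expected step is therefore small, a 1.0-fold higher number from compound 3 to compound 4 (0.00 log units; within the scatter), with no clear direction. Compound 4 is estimated at 8500 nM in this assay, within a range from 3000 nM to 25000 nM.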

Compound 4, half-maximal inhibitory concentration: 17900 nM
Compound 4: middle estimate off by 2.1-fold (0.32 log units), on the low side; low and high end bracket the measured number.
By their numbers in this assay, from the lowest: compounds 3, 2, 1 and 4 (each within the scatter of the next, the first and the last beyond it).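

For the compounds shown here, at the aromatic carbon para to a large group, the exchange of bromo for ethyl gives the first step to pass beyond the scatter in this assay, with a 2.1-fold higher number from compound 3 to compound 4 (0.33 log units; beyond the scatter) as a modest change, so this carbon is not indifferent to every exchange, as the halogen pair alone might have suggested. Going by these compounds alone, the reach of that finding is narrow, since ethyl in place of fluoro at the same carbon stays within the scatter, with a 1.9-fold higher number from compound 2 to compound 4 (0.27 log units; within the scatter) as its step, and the replacement of the whole aryl group also stays within it, with a 1.2-fold higher number from compound 1 to compound 4 (0.09 log units; within the scatter) as its step, leaving only the pair of compound 3 and compound 4 separated. Nothing available here accounts for the step from bromo to ethyl.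

On these data alone, it remains open whether the separation follows ethyl itself or would also appear with methyl, a longer propyl chain, or a methoxy group at this carbon. An amine or a carboxylic acid there could show whether this carbon tolerates a larger departure from the groups seen so far, and all four compounds remain weak enough that any such change would have to be read against the same scatter.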